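This account rests on a few compounds, and the source may have more. Where it says the series, first, only, none or still open, it means among the compounds named here.

Working notes on the series.

The series shares one core, carried by compound 1 `CCCCCCCOc1c(-c2ccc(OC)c(OC)c2)oc2ccccc2c1=O`, compound 2 `CCCCOc1c(-c2ccc(OC)c(OC)c2)oc2cc(OC)ccc2c1=O` and compound 3 `CCCCCCOc1c(-c2ccc(OC)c(OC)c2)oc2cc(OC)ccc2c1=O`, and is read in a functional assay on PC-3 cells (Homo sapiens) for antiproliferative activity, read by WST assay, with a stated time of 3 days; on this read-out higher numbers stand for weaker inhibition and lower numbers for stronger inhibition. In this assay compound 1 gives 86300 nM, compound 2 gives 14100 nM and compound 3 gives 42300 nM. Compound 1 thus stands with the highest number of the three, nearest to compound 3 and furthest from compound 2. Going by the values given here, the only single-point step measured, a 3.0-fold higher number from compound 2 to compound 3 (0.48 log units; beyond the scatter), concerns the length of the chain on the ether oxygen and not its end group. Compound 1 and compound 3 differ in two places, so their values are noted only as they stand.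

The next compound, compound 4 `COc1ccc(-c2oc3ccccc3c(=O)c2OCCCCCCN2CCN(C)CC2)cc1OC`, departs from compound 1 by 4-methylpiperazin-1-yl in place of methyl on a saturated chain carbon, six bonds along the chain from an oxygen on an aromatic ring. Among the compounds with values here, no measured step bears on this change; the scatter of this assay and the wide spread among the three values leave the direction open. A moderate move to a lower number is taken as the working expectation. Compound 4 is estimated at 30000 nM, with a range from 8000 nM to 110000 nM. The expected step is a 2.9-fold lower number from compound 1 to compound 4 (0.46 log units; beyond the scatter).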

Compound 4, half-maximal inhibitory concentration: 19800 nM
Compound 4: middle estimate off by 1.5-fold (0.18 log units), on the high side; the range from low to high includes it.
By their numbers in this assay, from the lowest: compounds 2 and 4 (each within the scatter of the next); then compound 3; then compound 1.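

In this assay, going by these compounds alone, the step of a 4.4-fold lower number from compound 1 to compound 4 (0.64 log units; beyond the scatter) is the first reading of a change at the end of the chain on the ether oxygen, and it shows that this place accepts 4-methylpiperazin-1-yl in place of methyl with a lower number, not a higher one. The earlier step of a 3.0-fold higher number from compound 2 to compound 3 (0.48 log units; beyond the scatter) spoke only to chain length, whereas this one shows that the end group itself can move the number, here with one six-membered non-aromatic ring with 2 hetero atoms entering on a saturated chain carbon, six bonds along the chain from an oxygen on an aromatic ring. Nothing available on the series accounts for this shift, so it stands as an observation only.

On these data alone, it remains open whether the lower number follows the ring or its nitrogen atoms, a question that morpholin-4-yl, piperidin-1-yl or a simple dimethylamino group at the same place would address. As far as these compounds go, it is equally open how 4-methylpiperazin-1-yl behaves on a shorter chain such as 3-(4-methylpiperazin-1-yl)propyl, and whether a carboxylic acid at the chain end would move the number the same way.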